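The compounds below may be only part of what the source reports. "The series", "measured", "known", "first", "only" and "open" are said of these compounds alone.

In a functional assay on VCaP cells (Homo sapiens) for antiproliferative activity, read by CCK-8 assay, with a stated time of 6 days (on this read-out lower numbers stand for stronger inhibition and higher numbers for weaker inhibition), compound 2 `CCN(c1ccc(C#N)c(Cl)c1)c1cc(-c2ccco2)ccc1C` gives > 30000 nM, which is a limit of the assay and not a number. Compound 1 `Cn1nccc1-c1cccc2c1CCCN2c1ccc(C#N)c(C(F)(F)F)c1` gives > 30000 nM, also a limit. Compound 3 `Cc1noc(C)c1-c1cccc2c1CCCN2c1ccc(C#N)c(C(F)(F)F)c1` gives > 30000 nM, again a limit. The whole record so far is therefore (the limit of > 30000 nM in this assay, at which 3 of the 3 values shown sit).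

Compound 4 `CCN(c1ccc(C#N)c(Cl)c1)c1cc(-c2c[nH]nc2C)ccc1C` differs from compound 2 in one place: 3-methyl-1H-pyrazol-4-yl in place of furan-2-yl on an aromatic carbon. The new group, 3-methyl-1H-pyrazol-4-yl, takes the place of furan-2-yl on an aromatic carbon, para to a methyl group.

Within the data shown here, only one measured step bears on this change, and only loosely. It also exchanges one five-membered aromatic group for another on an aromatic carbon, but on a different core: a step that the two limits leave unreadable from compound 1 to compound 3. Its size cannot be read, so it offers no size to carry over. With compound 3 at > 30000 nM, it shows no gain from such an exchange, though it does not rule one out. In this assay, the expectation is therefore at most a modest move towards stronger inhibition, with a real chance that only a limit is reported again. The expected change is an at least 1.6-fold lower number from compound 2 to compound 4 (0.22 log units; that floor lies within the scatter). For compound 4 the estimated value is 18000 nM, with an expected range of 4000 nM to 40000 nM.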

Compound 4, half-maximal inhibitory concentration: 3190 nM
The estimate for compound 4 lay 5.6-fold (0.75 log units) above the measured number; measured number below the stated range.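

In this assay, replacing furan-2-yl with 3-methyl-1H-pyrazol-4-yl gives an at least 9.4-fold lower number from compound 2 to compound 4 (0.97 log units; beyond the scatter), so the choice of five-membered aromatic ring at this place, para to a methyl group, can move the read-out, and compound 4 alone among the four compounds gives a real number. The earlier compounds shown here could not show this, since all of them stood at a single limit: the limit of > 30000 nM in this assay, at which 3 of the 4 values shown sit. As far as these compounds go, because compound 2 is itself only a limit, the true size of the step stays unknown, and the step gives only its lower bound: the limit of > 30000 nM in this assay, at which 3 of the 4 values shown sit.

What the compounds shown leave open is which part of the new group carries the step: the hydrogen-bond donor, the methyl group or the second ring nitrogen. From the compounds shown here alone, a 1H-pyrazol-4-yl without the methyl, or a 1-methyl-1H-pyrazol-4-yl, at this place would tell these apart, and whether 3-methyl-1H-pyrazol-4-yl does the same on the core of compound 1 is equally open.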